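The source may report more compounds than this note shows. Statements on the series, on what has been measured and on what is new or still open speak of the compounds shown alone.

Measured compounds:
compound 1, `CCc1ccc(-c2ccc(N(C[C@@H](N)[C@@H](C)CC)C(=O)[C@@H]3C[C@H]3c3ccccc3)cc2)cc1`, 44 nM
compound 2, `CCCc1ccc(-c2ccc(N(C[C@@H](N)[C@@H](C)CC)C(=O)[C@@H]3C[C@H]3c3ccccc3)cc2)cc1`, 61 nM
compound 3, `CC[C@H](C)[C@H](N)CN(C(=O)[C@@H]1C[C@H]1c1ccccc1)c1ccc(-c2ccc(OC(C)C)cc2)cc1`, 72 nM

In a functional assay for agonist activity at G protein-coupled receptor 88 (Homo sapiens), read by HTRF and cAMP accumulation (a lower number here means that less compound is needed, a higher number that more compound is needed for the effect), compound 3 gives the highest of the three numbers, but it sits close to the others: a 1.2-fold higher number from compound 2 to compound 3 (0.07 log units; within the scatter) and a 1.6-fold higher number from compound 1 to compound 3 (0.21 log units; within the scatter). Compound 4, `CC[C@H](C)[C@H](N)CN(C(=O)[C@@H]1C[C@H]1c1ccccc1)c1ccc(-c2ccc(OC(F)(F)F)cc2)cc1`, differs from compound 3 by trifluoromethyl in place of isopropyl on an oxygen on an aromatic ring. The measured steps that bear on this place all alter the substituent on the aromatic carbon itself; none changes what sits on the oxygen. Since those steps stayed within the scatter, the step to compound 4 is expected to be small as well: a 1.0-fold lower number from compound 3 to compound 4 (0.01 log units; within the scatter). Compound 4 is therefore estimated at 70 nM, with a range from 25 nM to 200 nM.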

Compound 4, half-maximal effective concentration: 170 nM
Beside the measured number, compound 4's estimate is 2.4-fold (0.39 log units) below it, and the stated range covers the measured number.
By their numbers in this assay, from the lowest: compounds 1, 2 and 3 (each within the scatter of the next); then compound 4.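

In this assay, what sits on the oxygen matters: trifluoromethyl in place of isopropyl gives a change beyond the scatter (a 2.4-fold higher number from compound 3 to compound 4 (0.37 log units; beyond the scatter)). Trifluoromethoxy also moves beyond the scatter when set against the alkyl groups on the aromatic carbon (a 2.8-fold higher number from compound 2 to compound 4 (0.45 log units; beyond the scatter); a 3.9-fold higher number from compound 1 to compound 4 (0.59 log units; beyond the scatter)), whereas isopropoxy in that place stayed within it. Nothing available here explains this difference.

The compounds shown leave open how methoxy or difluoromethoxy would read in this place. They therefore cannot separate the entry of the fluorine atoms from the departure of the isopropyl carbons.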